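The source may report more compounds than this note shows. Statements on the series, on what has been measured and on what is new or still open speak of the compounds shown alone.

Measured so far in this series:
compound 1 `O=C1C(Cc2n[nH]c3cc(F)ccc23)C(=O)N(c2ccccc2)C=CN1CC(=O)N1CCCCc2ccccc21` — 1.59 nM
compound 2 `CC(C)N(C(=O)CN1C=CN(c2ccccc2)C(=O)C(Cc2n[nH]c3ccccc23)C1=O)c1ccc(OC(F)(F)F)cc1` — 22.4 nM
compound 3 `COc1ccc(N(C(=O)CN2C=CN(c3ccccc3)C(=O)C(Cc3n[nH]c4ccccc34)(OC)C2=O)C(C)C)cc1` — 1380 nM

In a functional assay on CHO cells for agonist activity at Melanocyte-stimulating hormone receptor (Homo sapiens), read by a luciferase reporter, with a stated time of 4 h (a higher number here means that more compound is needed for the effect, a lower number that less compound is needed), compound 1 gives 1.59 nM, the lowest number of the three; compound 2 gives 22.4 nM, a higher number beyond the scatter, and compound 3 gives 1380 nM, higher again and furthest from compound 1.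

Compound 4 `CC(C)N(C(=O)CN1C=CN(c2ccccc2)C(=O)C(Cc2n[nH]c3cc(F)ccc23)C1=O)c1ccc(F)cc1` has not yet been measured in this assay. Relative to compound 1 the change is a group of 11 heavy atoms (9 carbon, 1 nitrogen, 1 fluorine; one six-membered aromatic ring of carbon only) in place of a group of 11 heavy atoms (10 carbon, 1 nitrogen; one six-membered aromatic ring of carbon only, one seven-membered non-aromatic ring with 1 hetero atom), on a carbonyl carbon. Among the measured compounds shown here, no two measured compounds differ in one place only, so there is no step on record to set the size of this change directly. Compound 2 shows that an amide carrying an isopropyl group and a six-membered aromatic ring, on a core without fluorine, still gives a number well below that of compound 3, but it does not isolate the seven-membered ring.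

The step in this assay is expected to be a modest rise, likely beyond the scatter yet smaller than the gap seen between compound 1 and compound 2; the step from compound 1 to compound 4 is estimated at a 4.4-fold higher number from compound 1 to compound 4 (0.64 log units; beyond the scatter). Compound 4 is expected to give about 7 nM, within a range of 2 nM to 35 nM.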

Compound 4, half-maximal effective concentration: 14.1 nM
Compound 4: the middle estimate sits 2.0-fold (0.30 log units) below what was measured, within the range that was stated.
By their numbers in this assay, from the lowest: compound 1; then compounds 4 and 2 (each within the scatter of the next); then compound 3.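

In this assay, among the compounds shown here, with the shared core held constant, the group on the carbonyl carbon gives the first readable step: an 8.9-fold higher number from compound 1 to compound 4 (0.95 log units; beyond the scatter). This shows that the position responds to the change from the group with the seven-membered non-aromatic ring to the group without it, although the open amide of compound 4 still reads 14.1 nM. Nothing on record explains the size of this step.

The step changes the ring, the fluorine and the isopropyl group together, so the contribution of each remains unresolved. The compounds shown also leave open how a piperidine or a dimethylamine would read on the same carbonyl carbon, and whether an open group without fluorine would give a different number on this core.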